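Alkyl chain extension on the core of compound 1

This account rests on a few compounds, and the source may have more. Where it says the series, first, only, none or still open, it means among the compounds named here.

Measured so far in an assay on isolated protein for inhibition of leukotriene B4 receptor 1 (Homo sapiens), tested at 10 uM; a lower number here means less inhibition, a higher number more inhibition at the concentration tested (going by the name of the read-out):
compound 1 `CC(=O)c1ccc(OCCCCC#N)cc1O` gives 0%
compound 2 `CCc1cc(C(C)=O)c(O)cc1OCCCCC#N` gives 92%
compound 3 `CCCc1cc(C(C)=O)c(O)cc1OCCCCC#N` gives 84%

Compound 3 stands second highest of the three numbers. Its nearest neighbour is compound 2, the gap being a number 8 percentage points lower from compound 2 to compound 3 (within the scatter), while compound 1 lies far off, a number 84 percentage points higher from compound 1 to compound 3 (beyond the scatter). Compound 4 `CCCCc1cc(C(C)=O)c(O)cc1OCCCCC#N` differs from compound 3 by methyl in place of hydrogen on a saturated chain carbon, three bonds along the chain from an aromatic carbon. Among the measured compounds shown here, the steps that bear on this are a number 92 percentage points higher from compound 1 to compound 2 (beyond the scatter) and a number 84 percentage points higher from compound 1 to compound 3 (beyond the scatter), both large, whereas the further lengthening a number 8 percentage points lower from compound 2 to compound 3 (within the scatter) stays within the scatter. Only the latter is a lengthening of an alkyl already present, so for compound 4 a step within the scatter, or at most a small drop, is expected in this assay. Compound 4 is estimated at 80%, between 60% and 95%. The expected step is a number 4 percentage points lower from compound 3 to compound 4 (within the scatter).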

Compound 4, a percentage reported as inhibition, at one concentration (the size of the read-out at that concentration, not a potency): 41%
The estimate for compound 4 lay 39 percentage points above the measured number, and the stated range ends above it.
By their numbers in this assay, from the lowest: compound 1; then compound 4; then compounds 3 and 2 (each within the scatter of the next).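

In this assay the propyl to butyl change gives a number 43 percentage points lower from compound 3 to compound 4 (beyond the scatter) and the ethyl to butyl change gives a number 51 percentage points lower from compound 2 to compound 4 (beyond the scatter) as well, so lengthening at this position is no longer neutral once the chain reaches butyl. The butyl chain still gives a number 41 percentage points higher from compound 1 to compound 4 (beyond the scatter) so the gain is reduced, not lost. No measurement at hand explains the drop.

Going by these compounds, whether a longer chain such as pentyl or hexyl falls further remains open. So does how a branched isobutyl or a cyclopropyl group compares with butyl here.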